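This account rests on a few compounds, and the source may have more. Where it says the series, first, only, none or still open, it means among the compounds named here.

Measured compounds:
compound 1, `O=C(Nc1ccc(S(=O)(=O)Nc2cccc(Cl)c2)cc1)c1ccc(Cl)cc1Cl`, 575 nM in a functional assay on HEK293 cells for agonist activity at probable G-protein coupled receptor 27 (Homo sapiens), read by a luciferase reporter and beta-arrestin recruitment, with a stated time of 10 min; a lower number here means that less compound is needed, a higher number that more compound is needed for the effect
compound 2, `O=C(Nc1ccc(S(=O)(=O)Nc2ccccc2Cl)cc1)c1ccc(Cl)cc1Cl`, 1260 nM

Of these two, compound 2 gives the higher number in this assay, needing more compound than compound 1 does; the step between them, a 2.2-fold higher number from compound 1 to compound 2 (0.34 log units; beyond the scatter), lies beyond the scatter. Compound 3, `Cc1ccccc1NS(=O)(=O)c1ccc(NC(=O)c2ccc(Cl)cc2Cl)cc1`, has not yet been measured. Compound 3 differs from compound 2 by one exchange: methyl in place of chloro on an aromatic carbon.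

Among the measured compounds shown here, only one measured step exists, and it concerns where the chloro sits on that ring, not what takes its place. For the measured compounds named here, no measured step therefore bears directly on an exchange of chloro for methyl on this ring. With nothing to point either way, the step from compound 2 to compound 3 is expected to stay within the scatter, a 1.1-fold lower number from compound 2 to compound 3 (0.06 log units; within the scatter). Compound 3 is accordingly estimated at 1100 nM, within a range from 450 nM to 2700 nM.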

Compound 3, half-maximal effective concentration: 1230 nM
Compound 3: the middle estimate sits 1.1-fold (0.05 log units) below what was measured; low and high end bracket the measured number.
By their numbers in this assay, from the lowest: compound 1; then compounds 3 and 2 (each within the scatter of the next).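

In this assay, the exchange of chloro for methyl on an aromatic carbon, ortho to a large group, leaves the number within the scatter (a 1.0-fold lower number from compound 2 to compound 3 (0.01 log units; within the scatter)), so at this place the two groups cannot be told apart. Compound 3 also keeps the gap to compound 1 that the earlier step had shown, and that gap stays beyond the scatter (a 2.1-fold higher number from compound 1 to compound 3 (0.33 log units; beyond the scatter)); among these three compounds, 2-chlorophenyl and 2-methylphenyl both read above 3-chlorophenyl, with no compound going against this. Nothing at hand explains why chloro and methyl read alike here.

As far as these compounds go, whether methyl would also match chloro on compound 1's 3-chlorophenyl group stays open. So does how an amine or a carboxylic acid would read in place of the methyl of compound 3.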